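The compounds below may be only part of what the source reports. "The series", "measured", "known", "first", "only" and "open" are said of these compounds alone.

Of the compounds shown here, two have so far been tested in a functional assay on cells (Cancer cell lines, Homo sapiens) for cytotoxicity, with a stated time of 48 h; on this read-out higher numbers stand for weaker inhibition of growth and lower numbers for stronger inhibition of growth. Compound 1 `COc1c(/C=C2/C(=O)Nc3ccc(Cl)cc32)c2ccccc2n1-c1ccccc1` gives 4270 nM. Compound 2 `COc1cc2c(cc1C)NC(=O)/C2=C/c1c(Cl)n(Cc2cc(OC)c(OC)c(OC)c2)c2cc(C)c(OC)cc12` gives 10000 nM, the highest of the two numbers, and its gap from compound 1 lies beyond the usual scatter. Compound 3 `COc1ccc2c(c1)/C(=C\c1c(Cl)n(Cc3cc(OC)c(OC)c(OC)c3)c3cc(C)c(OC)cc13)C(=O)N2` differs from compound 2 in a single place: hydrogen in place of methyl on an aromatic carbon. Among the compounds with values here, no measured pair shows this kind of change, so only a small step is expected, possibly toward a lower number, and it may well stay within the scatter. Compound 3 is therefore estimated at 8000 nM, in a range from 3000 nM to 20000 nM, an expected step of a 1.3-fold lower number from compound 2 to compound 3 (0.10 log units; within the scatter).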

Compound 3, concentration for 50% growth inhibition: 10200 nM
The estimate for compound 3 lay 1.3-fold (0.11 log units) below the measured number; the measured number falls inside the stated range.
By their numbers in this assay, from the lowest: compound 1; then compounds 2 and 3 (each within the scatter of the next).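

In this assay, within the data shown here, this is the first pair of compounds differing in one place, and replacing the methyl with hydrogen on this aromatic carbon, ortho to a methoxy group, gives a 1.0-fold higher number from compound 2 to compound 3 (0.01 log units; within the scatter). At this position, in this setting, the two groups therefore cannot be told apart. Nothing available explains this result. Still open, on these data alone, is whether a different group on this carbon, such as an amine or a carboxylic acid, would also leave the number within the scatter.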